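The source may hold more compounds than are shown below. What is called first, only, known or untested is meant among the compounds shown, and "the series" means these compounds.

Compound 1 `CC(C)(c1cc([C@@]23CCOC[C@@H]2C3)nc(-c2cccc(O)c2)n1)S(C)(=O)=O`: 148 ug/mL
Compound 2 `CC(C)(c1cc([C@@]23CCOC[C@@H]2C3)nc(-c2ccc(NC(=S)NCCO)cc2)n1)S(C)(=O)=O`: 145 ug/mL
Compound 3 `CC(C)(c1cc([C@]23CCOC[C@H]2C3)nc(-c2cccc(O)c2)n1)S(C)(=O)=O`: 135 ug/mL

These values come from a physicochemical assay for solubility, in phosphate buffer, measured as kinetic solubility, with a stated time of 1 h, at pH 7.4; on this read-out lower numbers stand for lower solubility and higher numbers for higher solubility. The three numbers lie within the usual scatter of one another, so compound 1 stands level with compound 2 and compound 3.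

Compound 4 `CS(=O)(=O)Cc1cc([C@@]23CCOC[C@@H]2C3)nc(-c2cccc(O)c2)n1` differs from compound 1 in one place: (methylsulfonyl)methyl in place of 1-methyl-1-(methylsulfonyl)ethyl on an aromatic carbon. In words, (methylsulfonyl)methyl stands in place of 1-methyl-1-(methylsulfonyl)ethyl on an aromatic carbon of the shared core.

Going by the values given here, only one measured step is available as a guide: a 1.1-fold lower number from compound 1 to compound 3 (0.04 log units; within the scatter). It lies within the scatter, but it rests on (the fact that compounds 1 and 3 differ only in the configuration as drawn), so the 1-methyl-1-(methylsulfonyl)ethyl group stays the same across it. Among the compounds with values here, no measured step shows what replacing this group does, so the guide is indirect. On that limited basis, no shift beyond the scatter is expected in this assay, and no direction can be favoured. The estimated step is a 1.0-fold higher number from compound 1 to compound 4 (0.01 log units; within the scatter). The expected value for compound 4 is 150 ug/mL, with an estimated range of 75 ug/mL to 300 ug/mL.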

Compound 4, solubility: 145 ug/mL
Compound 4: middle estimate off by 1.0-fold (0.01 log units), on the high side, and the stated range covers the measured number.
By their numbers in this assay, from the lowest: compounds 3, 2, 4 and 1 (each within the scatter of the next).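

Going by these compounds alone, this is the first measured change at this position, on an aromatic carbon of the shared core, and in this assay it gives a 1.0-fold lower number from compound 1 to compound 4 (0.01 log units; within the scatter). The 7 heavy atoms of 1-methyl-1-(methylsulfonyl)ethyl can therefore give way to the 5 of (methylsulfonyl)methyl, with the hydrogen-bond donor and acceptor counts unchanged, and the read-out stays within the scatter for this pair. Nothing available accounts for this outcome.

The compounds shown leave open whether a group lacking the methylsulfonyl unit at this position, such as an amine, a carboxylic acid or a longer alkyl chain, would also stay within the scatter. They also leave open whether this same replacement would read alike in compound 2 or compound 3.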